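A few compounds are considered here, and "the series" means these few. Any claim that something is new, unique, unknown or untested is made for them only; others in the source may bear on it.

Within the data shown here, compound 3 `COc1cccc(-c2c(C)n(Cc3c(F)cccc3F)c(=O)n(C[C@H](N)C(C)C)c2=O)c1F` holds the second highest of the three numbers measured so far in an assay on HEK293 cells for binding affinity to Gonadotropin-releasing hormone receptor (Homo sapiens), read by radioligand binding (on this read-out lower numbers stand for stronger inhibition and higher numbers for weaker inhibition), where compound 3 gives 51 nM. Its nearest neighbour is compound 2 `COc1cccc(-c2c(C)n(Cc3c(F)cccc3F)c(=O)n(C[C@H](N)CC(C)C)c2=O)c1F`, which in this assay gives 6.4 nM; the step of an 8.0-fold higher number from compound 2 to compound 3 (0.90 log units; beyond the scatter) is modest. The furthest is compound 1 `COc1cccc(-c2c(C)n(Cc3c(F)cccc3F)c(=O)n(C[C@@H](N)CCc3ccccc3)c2=O)c1F`, which gives 965 nM; the steps of a 150-fold lower number from compound 1 to compound 2 (2.18 log units; beyond the scatter) and a 19-fold lower number from compound 1 to compound 3 (1.28 log units; beyond the scatter) were both large. Compound 4 `COc1cccc(-c2c(C)n(Cc3c(F)cccc3F)c(=O)n(C[C@@H](N)C(C)C)c2=O)c1F` is related to compound 3 in that (the two compounds have the same atoms and bonds and differ only in configuration as drawn: 1 of 1 stereo elements differ; a stereocentre at a saturated chain carbon is drawn R in compound 3 and S in compound 4). Among the measured compounds shown here, none of the measured steps bears directly on this change, since each of them swaps the group on the saturated chain carbon rather than its configuration alone, so no measured guide exists for its size or direction. Compound 4 is nonetheless expected to give a higher number, estimated at 400 nM with a range from 80 nM to 2000 nM, an expected step of a 7.8-fold higher number from compound 3 to compound 4 (0.89 log units; beyond the scatter).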

Compound 4, inhibition constant: 973 nM
Compound 4: the middle estimate sits 2.4-fold (0.39 log units) below what was measured; the range from low to high includes it.
By their numbers in this assay, from the lowest: compound 2; then compound 3; then compounds 1 and 4 (each within the scatter of the next).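

Configuration alone at this saturated chain carbon carries real weight, a point the earlier swaps of the group could not show, as a 19-fold higher number from compound 3 to compound 4 (1.28 log units; beyond the scatter) shows: the fact that compounds 3 and 4 differ only in the configuration as drawn Against the 1-amino-3-methylbutyl compound the gap is wider still, with a 150-fold higher number from compound 2 to compound 4 (2.18 log units; beyond the scatter). The phenethyl compound cannot be told apart from compound 4, given a 1.0-fold higher number from compound 1 to compound 4 (0.00 log units; within the scatter).

From the compounds shown here alone, it remains open whether the mirror-image form of compound 2 would lose as much. Going by these compounds, whether a cyclohexyl group on this carbon would favour the same configuration also remains open.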